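Widening a Saturated Ring on the Aromatic Core

The source may hold more compounds than are shown below. What is called first, only, known or untested is meant among the compounds shown, and "the series" means these compounds.

Compound 3 `CC(C(=O)NCc1ccc(C(C)(C)C)cc1N1CCCC1)c1ccc(NS(C)(=O)=O)c(F)c1` is the weakest of three compounds in an assay on cells for antagonist activity at transient receptor potential cation channel subfamily V member 1 (Homo sapiens), read by FLIPR and calcium flux, with a stated time of 6 min (a lower number here means a stronger inhibitor, a higher number a weaker inhibitor), where compound 3 gives 8.1 nM. Compound 1 `CC(C(=O)NCc1ccc(C(C)(C)C)nc1N1CCCC1)c1ccc(NS(C)(=O)=O)c(F)c1` gives 1.2 nM, and compound 2 `CCCCCCOc1nc(C(C)(C)C)ccc1CNC(=O)C(C)c1ccc(NS(C)(=O)=O)c(F)c1` gives 2.7 nM. Compound 4 `CC1CCN(c2cc(C(C)(C)C)ccc2CNC(=O)C(C)c2ccc(NS(C)(=O)=O)c(F)c2)CC1` carries 4-methylpiperidin-1-yl in place of pyrrolidin-1-yl on an aromatic carbon. Within the data shown here, no measured step swaps one saturated ring for another. Among the measured compounds shown here, the only step that removes a pyrrolidin-1-yl group, a 2.3-fold higher number from compound 1 to compound 2 (0.35 log units; beyond the scatter), replaced it with a hexyloxy chain on a different core and weakened binding modestly. A larger saturated ring is therefore expected to leave potency close to that of compound 3, with the step of a 1.0-fold lower number from compound 3 to compound 4 (0.01 log units; within the scatter) expected to stay small. Compound 4 is estimated at 8 nM, with a likely range from 3 nM to 25 nM.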

Compound 4, inhibition constant: 0.7 nM
For compound 4 the middle estimate is 11-fold (1.06 log units) above the measured one; measured number below the stated range.
By their numbers in this assay, from the lowest: compounds 4 and 1 (each within the scatter of the next); then compound 2; then compound 3.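

On this aromatic carbon, the change of saturated ring gives a 12-fold lower number from compound 3 to compound 4 (1.06 log units; beyond the scatter) in this assay, so the ring held here can alter the measured number substantially. The earlier step, a 2.3-fold higher number from compound 1 to compound 2 (0.35 log units; beyond the scatter), was modest, but it replaced the ring with a chain rather than with another ring. Nothing available explains the size of this step.

Plain piperidin-1-yl, without the methyl, would help show whether the larger ring or the methyl accounts for the step. Morpholin-4-yl would test an oxygen in that ring.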